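Replacing the carbonyl-bound group of compound 3

This account rests on a few compounds, and the source may have more. Where it says the series, first, only, none or still open, it means among the compounds named here.

In an ADME assay on Caco-2 cells (Homo sapiens) for permeability, in the apical to basolateral direction, with a stated time of 90 min, tested at 10 uM (a lower number here means that the compound crosses the layer more slowly, a higher number that the compound crosses the layer faster), compound 1 `O=C(NC[C@@H]1[C@H]2CN(C(=O)N3CCc4c(Cl)cc(Cl)cc4C3)C[C@@H]12)c1ccc2[nH]c(=O)oc2c1` gives 47 10^-6 cm/s and compound 2 `O=C(NC[C@@H]1[C@H]2CN(C(=O)OCc3cc(C(F)(F)F)cc(C(F)(F)F)c3)C[C@@H]12)c1ccc2[nH]c(=O)oc2c1` gives 108 10^-6 cm/s. Compound 3 `N#Cc1cc(COC(=O)N2C[C@@H]3[C@@H](CNC(=O)c4ccc5[nH]nnc5c4)[C@@H]3C2)cc(C(=O)OC(F)(F)F)c1` gives 8 10^-6 cm/s, the lowest of the three numbers and beyond the scatter from both others. Compound 4 `N#Cc1cc(COC(=O)N2C[C@@H]3[C@@H](CNC(=O)N4CCc5[nH]nnc5C4)[C@@H]3C2)cc(C(=O)OC(F)(F)F)c1` differs from compound 3 on a carbonyl carbon: a group of 9 heavy atoms (5 carbon, 4 nitrogen; one five-membered aromatic ring with 3 hetero atoms, one six-membered non-aromatic ring with 1 hetero atom) in place of a group of 9 heavy atoms (6 carbon, 3 nitrogen; one five-membered aromatic ring with 3 hetero atoms, one six-membered aromatic ring of carbon only), on a carbonyl carbon. For the measured compounds named here, no measured pair isolates this exchange, and compounds 1 and 2 differ from compound 3 in more than one place, so the data give no direct guide to its size. In this assay, a small upward move that stays within the scatter is expected. The expected step is a 1.5-fold higher number from compound 3 to compound 4 (0.18 log units; within the scatter). The estimate for compound 4 is 12 10^-6 cm/s, with an expected range of 4 10^-6 cm/s to 35 10^-6 cm/s.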

Compound 4, apparent permeability in the Caco-2 assay: 7 10^-6 cm/s
Compound 4: middle estimate off by 1.7-fold (0.23 log units), on the high side; low and high end bracket the measured number.
By their numbers in the Caco-2 assay, from the lowest: compounds 4 and 3 (each within the scatter of the next); then compound 1; then compound 2.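

In the Caco-2 assay the exchange on the carbonyl carbon gives a 1.1-fold lower number from compound 3 to compound 4 (0.06 log units; within the scatter), so the six-membered non-aromatic ring with 1 hetero atom and the six-membered aromatic ring of carbon only cannot be told apart by this read-out. For the compounds shown here, in a physicochemical assay for solubility, with a stated time of 24 h, at pH 2.2 (a higher number here means a more soluble compound, a lower number a less soluble compound), the same exchange gives an at least 32-fold higher number from compound 3 to compound 4 (1.50 log units; beyond the scatter), which the earlier compounds could not show at this position. In the physicochemical assay compound 3 gives < 1 ug/mL, which is a limit of the assay and not a number. In the physicochemical assay compound 4 gives 32 ug/mL.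

On these data alone, whether this separation between the two read-outs holds for other groups on this carbonyl carbon remains open, for example an open-chain amine or a chain ending in a carboxylic acid.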